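Phenyl for isopropyl on the ring amide nitrogen

The source may hold more compounds than are shown below. What is called first, only, known or untested is meant among the compounds shown, and "the series" means these compounds.

Among the compounds with values here, in a functional assay on MCF7 cells (Homo sapiens) for antiproliferative activity, read by MTT assay, with a stated time of 72 h (on this read-out lower numbers stand for stronger inhibition and higher numbers for weaker inhibition), compound 2 `CC(C)N1C(=O)COc2ccc(-c3cnc(Cl)c(NS(=O)(=O)c4ccc(F)cc4)c3)cc21` gives 26600 nM as the only actual number so far. Compound 1 `COc1cccc(N2C(=O)COc3ccc(-c4cnc(OC)c(NS(=O)(=O)c5ccc(F)cc5)c4)cc32)c1` gives > 40000 nM in this assay and this value is a limit of the assay, not a number. Compound 3 `O=C1COc2ccc(-c3cnc(Cl)c(NS(=O)(=O)c4ccc(F)cc4)c3)cc2N1c1ccccc1` carries phenyl in place of isopropyl on an amide-type nitrogen in a ring, and phenyl in place of isopropyl on an amide-type nitrogen in a ring is the counted change from compound 2. Within the data shown here, no step between measured compounds shows what this swap does. The expectation therefore rests on compound 2 at 26600 nM alone. No change beyond the scatter is expected in this assay and neither direction is favoured. The expected move is a 1.1-fold lower number from compound 2 to compound 3 (0.03 log units; within the scatter) and no more. Compound 3 is estimated at 25000 nM within a range of 8000 nM to 60000 nM for now.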

Compound 3, half-maximal inhibitory concentration: > 40000 nM
Compound 3 ended at the assay's limit (the forecaster's own chance of this, stated with the estimate: 35%); middle value at least 1.6-fold (0.20 log units) from the limit.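

In this assay, the swap to phenyl on the amide-type nitrogen in the ring gives an at least 1.5-fold higher number from compound 2 to compound 3 (0.17 log units; that floor lies within the scatter), the first step read at this position, and it brings no lower number than isopropyl did. Adding the six-membered aromatic ring of carbon only at this nitrogen therefore yields no actual number for compound 3. The step remains a floor and not a measured size, because compound 3 carries a limit: the limit of > 40000 nM in this assay, at which 2 of the 3 values shown sit.

As far as these compounds go, whether the true size of this step lies beyond the scatter stays open. Also open, from the compounds shown here alone, is whether the amide hydrogen, an aminoethyl chain or a carboxylic acid on this nitrogen would give a clearly lower number than compound 2 at 26600 nM.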